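The source may hold more compounds than are shown below. What is called first, only, known or untested is meant among the compounds shown, and "the series" means these compounds.

In a functional assay on RAW264.7 cells (Mus musculus) for inhibition, with a stated time of 30 min (a lower number here means a stronger inhibitor, a higher number a weaker inhibitor), compound 1 `C=C1C(=O)OC[C@H]1CCOC(=O)Nc1cc(C(F)(F)F)cc(C(F)(F)F)c1` gives 960 nM, the higher and so weaker of the two results available. Compound 2 `C=C1C(=O)OC[C@H]1CCOC(=O)Nc1ccccc1` gives 390 nM, a gap beyond the scatter. Compound 3 `C=C1C(=O)OC[C@@H]1CCOC(=O)Nc1cc(C(F)(F)F)cc(C(F)(F)F)c1` keeps every atom and bond of compound 1: the two compounds have the same atoms and bonds and differ only in configuration as drawn: 1 of 1 stereo elements differ; a stereocentre at a saturated ring carbon is drawn S in compound 1 and R in compound 3. A stereocentre at a saturated ring carbon is drawn S in compound 1 and R in compound 3. Within the data shown here, no measured pair shows what this inversion does in this assay, so no direction can be favoured with confidence. The expected change is a 1.1-fold lower number from compound 1 to compound 3 (0.05 log units; within the scatter), which would lie within the scatter. Compound 3 is estimated at 850 nM, with an expected range from 350 nM to 2000 nM.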

Compound 3, half-maximal inhibitory concentration: 800 nM
Compound 3: middle estimate off by 1.1-fold (0.03 log units), on the high side, and the stated range covers the measured number.
By their numbers in this assay, from the lowest: compound 2; then compounds 3 and 1 (each within the scatter of the next).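

Among these compounds, this is the first measured pair to isolate the inversion, and it gives a 1.2-fold lower number from compound 1 to compound 3 (0.08 log units; within the scatter) in this assay. At this stereocentre, then, the assay does not separate the two drawn configurations, at least with the two trifluoromethyl groups present. The comparison is a clean test of configuration because nothing else changes: the fact that compounds 1 and 3 differ only in the configuration as drawn

From the compounds shown here alone, it remains open whether the inversion would be equally silent in compound 2, which lacks the two trifluoromethyl groups. The same question stands for an amine or a carboxylic acid in their place.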